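This account rests on a few compounds, and the source may have more. Where it says the series, first, only, none or still open, it means among the compounds named here.

Compound 1, `CN(C)CCCNc1nc(-c2ccc(NC(=O)Nc3ccccc3F)cc2)nc2ccsc12`, sits among three compounds that share one core and were compared in a functional assay on NCI-H460 cells (Homo sapiens) for cytotoxicity, read by MTT assay, with a stated time of 72 h; on this read-out higher numbers stand for weaker inhibition and lower numbers for stronger inhibition. In this assay compound 1 gives 530 nM, the second highest of the three numbers. Compound 2, `CN(C)CCCNc1nc(-c2ccc(NC(=O)Nc3ccc(F)cc3)cc2)nc2c(Cl)c(Cl)sc12`, gives 650 nM, which lies within the usual scatter of the number for compound 1. Compound 3, `CN(C)CCCNc1nc(-c2ccc(NC(=O)Nc3ccc(Cl)cc3)cc2)nc2c(Cl)c(Cl)sc12`, gives 230 nM, a number beyond the scatter below compound 1.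

The step to the unmeasured compound 4, `CN(C)CCCNc1nc(-c2ccc(NC(=O)Nc3ccc(Cl)cc3Cl)cc2)nc2ccsc12`, is 2,4-dichlorophenyl in place of 2-fluorophenyl on an amide-type nitrogen. Among the measured compounds shown here, only one measured step speaks to a change of this kind: the step of a 2.8-fold lower number from compound 2 to compound 3 (0.45 log units; beyond the scatter), a chloro in place of a fluoro on an aromatic carbon in a compound with two chloro groups on the core. That step points the way for compound 4, since the change from compound 1 to compound 4 also trades a fluoro for chloro, yet it does so with two chloro groups entering and on a core without chloro groups, so the measured step is only a partial guide.

On that basis compound 4 is expected to show a modest improvement, with the step from compound 1 estimated as a 2.1-fold lower number from compound 1 to compound 4 (0.33 log units; beyond the scatter), because of the size of a 2.8-fold lower number from compound 2 to compound 3 (0.45 log units; beyond the scatter). The estimate for compound 4 in this assay is 250 nM, with a range from 100 nM to 700 nM.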

Compound 4, half-maximal inhibitory concentration: 1020 nM
Compound 4: the middle estimate sits 4.1-fold (0.61 log units) below what was measured; measured number above the stated range.
By their numbers in this assay, from the lowest: compound 3; then compounds 1, 2 and 4 (each within the scatter of the next).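

On the amide-type nitrogen of the core without chloro groups, exchanging 2-fluorophenyl for 2,4-dichlorophenyl gives a 1.9-fold higher number from compound 1 to compound 4 (0.28 log units; within the scatter) in this assay, so this pair shows no difference that can be told from the usual scatter, even though a chloro takes the place of a fluoro and a second chloro enters. The clear step seen earlier, a 2.8-fold lower number from compound 2 to compound 3 (0.45 log units; beyond the scatter), therefore does not reappear here, and it cannot be read as a general gain from chloro on this outer ring, since that step was a single exchange on a core that carries two chloro groups. Nothing measured here bears on the reason for this result.

This one pair cannot separate the exchange of fluoro for chloro from the addition of the second chloro, nor can it show how 2,4-dichlorophenyl would read on the core with two chloro groups. Also open, on these data alone, is how a plain phenyl, or a phenyl carrying a methoxy group or an amine, would read on this same amide-type nitrogen.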